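Chain length at the alkyne: expectation for compound 3

The source may hold more compounds than are shown below. What is called first, only, known or untested is meant among the compounds shown, and "the series" means these compounds.

Measured so far:
compound 1 `CCCCCCC#Cc1cc(C)oc(=O)c1`: 20300 nM
compound 2 `CCCCC#Cc1cc(C)oc(=O)c1`: 15500 nM

For the measured compounds named here, in a functional assay on K562 cells (Homo sapiens) for inhibition (a lower number here means a stronger inhibitor, a higher number a weaker inhibitor), compound 2 holds the lowest of the two numbers; its only neighbour is compound 1, and the step of a 1.3-fold lower number from compound 1 to compound 2 (0.12 log units; within the scatter) lies within the scatter, so the two compounds are not separated by this assay.

Compound 3 `CCCCCC#Cc1cc(C)oc(=O)c1` is not yet measured. It differs from compound 2 by methyl in place of hydrogen on a saturated chain carbon, four bonds along the chain from a triple-bonded carbon. Going by the values given here, the one measured step that bears on this change is a 1.3-fold lower number from compound 1 to compound 2 (0.12 log units; within the scatter), which removes an ethyl at the same place on the chain; compound 3 sits between compound 1 and compound 2 in chain length. Because that step stayed within the scatter, no movement beyond the scatter is expected from the smaller change here, in either direction. The expected step is therefore a 1.1-fold higher number from compound 2 to compound 3 (0.04 log units; within the scatter), essentially flat. Compound 3 is estimated at 17000 nM in this assay, with a range from 8500 nM to 34000 nM.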

Compound 3, half-maximal inhibitory concentration: 11100 nM
Beside the measured number, compound 3's estimate is 1.5-fold (0.19 log units) above it, within the range that was stated.
By their numbers in this assay, from the lowest: compounds 3, 2 and 1 (each within the scatter of the next).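

In this assay the addition of methyl in place of hydrogen on a saturated chain carbon, four bonds along the chain from a triple-bonded carbon, gives a 1.4-fold lower number from compound 2 to compound 3 (0.15 log units; within the scatter) and so adds a second chain change at this place that stays within the scatter. The largest gap in the set, a 1.8-fold lower number from compound 1 to compound 3 (0.26 log units; within the scatter), also stays within the scatter, so the assay separates none of the three chains and gives no basis for a trend or a preferred length among compound 1, compound 2 and compound 3. No supporting measurement is available to explain these small steps.

The compounds shown leave open whether a much shorter or much longer chain, or a branched chain such as isopropyl or tert-butyl, would move this assay beyond the scatter at this place. They also leave open what an amine, a hydroxyl, a carboxylic acid or a phenyl ring at the end of the chain would do, so the tolerance of this position for anything other than a plain alkyl chain remains untested in the series as shown here.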